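Moving the Amino Group: 4-Aminophenyl to 3-Aminophenyl

This account rests on a few compounds, and the source may have more. Where it says the series, first, only, none or still open, it means among the compounds named here.

In a functional assay on NCI-H460 cells (Homo sapiens) for antiproliferative activity, read by MTT assay, with a stated time of 48 h (on this read-out lower numbers stand for stronger inhibition and higher numbers for weaker inhibition), compound 1 `COc1cc(-c2cccc3nc(-c4cccc(O)c4)oc23)cc(OC)c1OC` gives 1900 nM, while compound 2 `COc1cc(-c2cccc3nc(-c4ccc(N)cc4)oc23)cc(OC)c1OC` gives 310 nM, the lower of the two numbers. Compound 3 `COc1cc(-c2cccc3nc(-c4cccc(N)c4)oc23)cc(OC)c1OC` has not been measured. It has the same atoms as compound 2, joined differently, with 3-aminophenyl in place of 4-aminophenyl on an aromatic carbon.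

Among the compounds with values here, only one measured step bears on this change: a 6.1-fold lower number from compound 1 to compound 2 (0.79 log units; beyond the scatter), a modest step beyond the scatter. It swapped 3-hydroxyphenyl for 4-aminophenyl, so it changed the group and its numbering together and cannot separate the two. Compound 3 shares its amino group with compound 2 and its numbering with compound 1, so a middling result seems likely. In this assay, a moderately higher number than for compound 2 is expected, with an estimated step of a 2.3-fold higher number from compound 2 to compound 3 (0.35 log units; beyond the scatter). Compound 3 is estimated at 700 nM, within a range of 200 nM to 2500 nM.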

Compound 3, half-maximal inhibitory concentration: 2600 nM
Compound 3: the middle estimate sits 3.7-fold (0.57 log units) below what was measured; measured number above the stated range.
By their numbers in this assay, from the lowest: compound 2; then compounds 1 and 3 (each within the scatter of the next).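

In this assay, the place of the amino group on the phenyl ring matters by itself: with the group unchanged, 3-aminophenyl in place of 4-aminophenyl gives an 8.4-fold higher number from compound 2 to compound 3 (0.92 log units; beyond the scatter) and so separates numbering from group, which the earlier step could not do. With the numbering held instead, amino in place of hydroxy gives a 1.4-fold higher number from compound 1 to compound 3 (0.14 log units; within the scatter) and shows no difference between these two groups at that numbering, so the advantage of compound 2 appears only with the 4-aminophenyl arrangement. No measurement here explains why the numbering matters so much.

Still open, from the compounds shown here alone, is whether that advantage needs the amino group itself, or whether a methylamino group or a carboxylic acid on the same ring carbon would keep it.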